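Halogen swap on two cores: expectation for compound 4

The compounds below may be only part of what the source reports. "The series", "measured", "known", "first", "only" and "open" are said of these compounds alone.

Compound 1 `O=C(/C(=C\c1c(O)cc(O)cc1O)S(=O)(=O)c1ccccc1Br)c1ccc(Br)cc1` and compound 2 `O=C(/C(=C\c1c(O)cc(O)cc1O)S(=O)(=O)c1ccccc1Br)c1ccc(Cl)cc1` share one core; compound 3 `Cc1ccc(S/C(=C/c2c[nH]c3ccc(Cl)cc23)C(=O)c2ccc(Br)cc2)cc1` stands on another, and the difference between the two cores is not broken down here. In a functional assay on DU-145 cells (Homo sapiens) for inhibition, read by trypan blue exclusion, with a stated time of 96 h (on this read-out lower numbers stand for stronger inhibition of growth and higher numbers for weaker inhibition of growth), compound 1 gives 50000 nM and compound 2 gives 50000 nM. The change between them, (bromo in place of chloro on an aromatic carbon), made no change at the digits printed from compound 2 to compound 1 (within the scatter). Compound 3 gives 1000 nM in this assay, the lowest of the three numbers and beyond the scatter from both others.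

Compound 4 `Cc1ccc(S/C(=C/c2c[nH]c3ccc(Br)cc23)C(=O)c2ccc(Br)cc2)cc1` is not yet measured; it follows from compound 3 by bromo in place of chloro on an aromatic carbon. This is the same kind of change as from compound 2 to compound 1, not the same: there the place is on an aromatic carbon of a six-membered aromatic ring of carbon only, para to a large group, whereas here the ring is part of a fused or bridged system of two rings, meta to a fused ring and para to a fused ring. Among the compounds with values here, because the one measured instance of this change gave no change at the digits printed from compound 2 to compound 1 (within the scatter), the step for compound 4 is expected to be no change at the digits printed from compound 3 to compound 4 (within the scatter) in this assay. The estimate for compound 4 is 1000 nM, between 400 nM and 2500 nM.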

Compound 4, concentration for 50% growth inhibition: 1000 nM
Estimate against measurement, compound 4: no gap at the digits printed; measured number inside the range.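

In this assay, bromo in place of chloro on an aromatic carbon gave no change at the digits printed from compound 3 to compound 4 (within the scatter). The change therefore carried from one core to the other with the same outcome, although it sits at a different place on each: the same change on two cores in this assay, no change at the digits printed (within the scatter) from compound 2 to compound 1 and no change at the digits printed (within the scatter) from compound 3 to compound 4, 1.0-fold (0.00 log units) apart, within the scatter of two such steps. Within the data shown here, this rests on only two pairs and one assay, so it does not show that the exchange would behave alike at other places on these cores or on further cores, and it says nothing about the effect of the change in any other read-out.

The two cores differ in several places at once, so the compounds shown do not tell which of those differences separates the numbers of compound 1 and compound 2 from those of compound 3 and compound 4. Also open, from the compounds shown here alone, is whether a group other than a halogen, such as an amine, a methoxy group or a carboxylic acid, on the same aromatic carbon would shift the result in this assay.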